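This account rests on a few compounds, and the source may have more. Where it says the series, first, only, none or still open, it means among the compounds named here.

Measured so far in an assay on liver for inhibition of sterol O-acyltransferase 1 (Rattus norvegicus), using microsomes; a lower number here means a stronger inhibitor, a higher number a weaker inhibitor:
- compound 1, `CCCCCCCCCCCCn1nnc(C(C(=O)Nc2c(OC)cc(OC)cc2OC)c2ccc(-c3ccccc3)cc2)n1`, 221 nM
- compound 3, `CCCCCCCCCCCCn1nnc(C(C(=O)Nc2c(OC)cc(OC)cc2OC)c2ccccn2)n1`, 590 nM
- compound 2, `CCCCCCCCCCCCn1nnc(C(C(=O)Nc2c(C(C)C)cccc2C(C)C)c2nnn[nH]2)n1`, for which the assay gives only a limit, > 5000 nM

Compound 3 stands at the higher of the two numbers; its nearest neighbour is compound 1, the step being a 2.7-fold higher number from compound 1 to compound 3 (0.43 log units; beyond the scatter). The next compound, compound 4, `CCCCCCCCCCCCn1nnc(C(C(=O)Nc2c(C(C)C)cccc2C(C)C)c2ccccn2)n1`, keeps the pyridin-2-yl of compound 3 and changes the amide side: 2,6-diisopropylphenyl in place of 2,4,6-trimethoxyphenyl on an amide-type nitrogen.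

Going by the values given here, no measured step bears directly on this change; the one step known, from compound 1 to compound 3, alters the other substituent and leaves the amide untouched. Compound 2 carries the same 2,6-diisopropylphenyl amide as compound 4, but it also differs at the carbon bearing the aryl group, so its value cannot be read as a step; it shows only that with this amide the assay reached its limit, (the limit of > 5000 nM in this assay, at which 1 of the 3 values shown sits).

Compound 4 is therefore expected to be weaker than compound 3, by about a 3.1-fold higher number from compound 3 to compound 4 (0.48 log units; beyond the scatter), with a real chance of a limit rather than a number. The estimate for compound 4 in this assay is 1800 nM, within the range 500 nM to 6000 nM.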

Compound 4, half-maximal inhibitory concentration: 26 nM
Beside the measured number, compound 4's estimate is 69-fold (1.84 log units) above it; the measured number lies below the stated range.
By their numbers in this assay, from the lowest: compound 4; then compound 1; then compound 3. At a limit, above all of these: compound 2.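

In this assay, the amide side carries far more weight than the earlier data suggested: with pyridin-2-yl kept, 2,6-diisopropylphenyl in place of 2,4,6-trimethoxyphenyl on the amide-type nitrogen gives a 23-fold lower number from compound 3 to compound 4 (1.36 log units; beyond the scatter), a larger step than the earlier one at the other substituent, a 2.7-fold higher number from compound 1 to compound 3 (0.43 log units; beyond the scatter). Compound 2 gives a limit, not a number: the limit of > 5000 nM in this assay, at which 1 of the 4 values shown sits. With the 2,6-diisopropylphenyl amide held, pyridin-2-yl in place of 1H-tetrazol-5-yl gives an at least 190-fold lower number from compound 2 to compound 4 (2.28 log units; beyond the scatter), so this amide alone does not secure a low number.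

From the compounds shown here alone, it remains open whether the 2,6-diisopropylphenyl amide gives a step of similar size with 4-phenylphenyl on the chain carbon. Also open, going by these compounds, is how a 2,6-dimethylphenyl amide, or a carboxylic acid in place of pyridin-2-yl, would read in this assay.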